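The compounds below may be only part of what the source reports. "The series", "measured", "known", "first", "only" and "open" are said of these compounds alone.

Notes on the series. Compound 1 `C[C@@H](C(=O)N1CC2CC2C1)N1CCN(S(=O)(=O)c2ccc(C(C)(C)C)cc2)CC1`, compound 2 `C[C@@H](C(=O)N1CCC(F)(F)CC1)N1CCN(S(=O)(=O)c2ccc(C(C)(C)C)cc2)CC1` and compound 3 `CC(C(=O)N1CCC(F)(F)CC1)N1CCN(S(=O)(=O)c2ccc(C(C)(C)C)cc2)CC1` share one core and differ only in the group on the carbonyl carbon or in the drawn configuration at the saturated chain carbon. In an ADME assay on HepG2 cells (Homo sapiens) for inhibition, with a stated time of 48 h (on this read-out lower numbers stand for an effect already at smaller amounts and higher numbers for an effect only at larger amounts of compound), compound 1 gives > 40000 nM, which is a limit of the assay and not a number. In this assay compound 2 gives > 40000 nM, again a limit. In this assay compound 3 gives > 40000 nM, also a limit. The step that the two limits leave unreadable from compound 1 to compound 2 cannot be read because of the limit of > 40000 nM in this assay, at which 3 of the 3 values shown sit. The step that the two limits leave unreadable from compound 2 to compound 3 is likewise unreadable because of the limit of > 40000 nM in this assay, at which 3 of the 3 values shown sit, and the two structures differ only in drawing because of the fact that one of compounds 2 and 3 is drawn with a defined configuration and the other without, at the place where they differ. Compound 3 therefore stands at the limit, with no number to place it more closely.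

Compound 4 `CC(C(=O)N1CCc2ccccc21)N1CCN(S(=O)(=O)c2ccc(C(C)(C)C)cc2)CC1` differs from compound 3 by 2,3-dihydro-1H-indol-1-yl in place of 4,4-difluoropiperidin-1-yl on a carbonyl carbon. For the measured compounds named here, no measured step gives a readable size, so no direction or size of step in this assay can be derived from them, and the expectation is that compound 4 also remains at the limit. Compound 4 is estimated at 40000 nM in this assay, with a range from 10000 nM to 100000 nM. The expected step of a number no higher from compound 3 to compound 4 (the limit leaves the size open) thus amounts to none beyond the scatter.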

Compound 4, half-maximal effective concentration: > 40000 nM
Compound 4: a limit, no number; the forecaster's own chance of this, stated with the estimate: 80%; the middle value sits exactly at the limit.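

In this assay compound 4 gives > 40000 nM, again a limit and not a number. No step from compound 3 to compound 4 can be read because of this: the limit of > 40000 nM in this assay, at which 4 of the 4 values shown sit.

The compounds shown leave open whether the group on the carbonyl carbon or the drawn configuration changes the read-out in this assay at all.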